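The compounds below may be only part of what the source reports. "The series", "measured", "known", "first", "only" and "open" are said of these compounds alone.

Working notes on the thiazolidinedione series

Compound 1 `O=C1NC(=O)C(Cc2ccc(Oc3ccc(C(F)(F)F)cn3)cc2)S1` carries a trifluoromethyl-bearing pyridine linked through an ether to the shared core. For the measured compounds named here, in a functional assay for agonist activity at Free fatty acid receptor 1 (Homo sapiens), read by FLIPR, in the presence of a further agent that is not named here (on this read-out higher numbers stand for an effect only at larger amounts of compound and lower numbers for an effect already at smaller amounts), compound 1 gives 558 nM, the second highest of the three numbers measured so far. Going by the values given here, compound 2 `O=C1NC(=O)C(Cc2ccc(Oc3ncc(C(F)(F)F)cc3Cl)cc2)S1` gives 69 nM in this assay, and the single step of an 8.1-fold lower number from compound 1 to compound 2 (0.91 log units; beyond the scatter) is the only change within the set that has been measured in one place. Among the compounds with values here, compound 3 `O=C1NC(=O)C(Cc2ccc(Oc3cccc(C(F)(F)F)n3)cc2)S1`, in which the ring nitrogen sits elsewhere, gives 1640 nM; no step between compound 1 and compound 3 is counted, and the two values simply show compound 3 standing higher.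

Compound 4 `Cc1ccc(Oc2ccc(CC3SC(=O)NC3=O)cc2)nc1` differs from compound 1 by methyl in place of trifluoromethyl on an aromatic carbon. Within the data shown here, no measured step bears on this change: the one available step concerns chloro for hydrogen at another carbon, and nothing in the set replaces trifluoromethyl by methyl. The expectation therefore rests only on compound 1 itself and must be wide. A modestly higher number is estimated for compound 4, with the step of a 2.2-fold higher number from compound 1 to compound 4 (0.33 log units; beyond the scatter) expected to lie near the edge of the scatter. The estimate for compound 4 in this assay is 1200 nM, with a range from 400 nM to 4000 nM.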

Compound 4, half-maximal effective concentration: 4470 nM
Compound 4: middle estimate off by 3.7-fold (0.57 log units), on the low side; the measured number lies above the stated range.
By their numbers in this assay, from the lowest: compound 2; then compound 1; then compound 3; then compound 4.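

In this assay, for the compounds shown here, the step of an 8.0-fold higher number from compound 1 to compound 4 (0.90 log units; beyond the scatter) is the first reading of the aromatic carbon two atoms from the ring nitrogen and para to a large group, and it shows that this carbon does not tolerate the exchange of trifluoromethyl for methyl without a change beyond the scatter. Going by these compounds alone, the one earlier step of an 8.1-fold lower number from compound 1 to compound 2 (0.91 log units; beyond the scatter) concerned chloro in place of hydrogen at another carbon and ran toward a lower number, whereas this one runs toward a higher number, so two separate places on the ring of compound 1 now each move the value. The exchange takes 4 heavy atoms out and puts 1 in, but no measurement here says what in that exchange moves the value.

The compounds shown leave open whether the value follows the group at this carbon in any order, which a nitrile, a methoxy group or plain hydrogen in the same place would begin to settle. From the compounds shown here alone, it also remains open whether the same exchange gives a step of similar size when the chloro of compound 2 is present.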